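Compound 3 to Compound 4: a Longer Chain at the Aromatic Oxygen

The source may hold more compounds than are shown below. What is called first, only, known or untested is meant among the compounds shown, and "the series" means these compounds.

Of the compounds shown here, three built on one shared core have been measured in a functional assay on PANC-1 cells (Homo sapiens) for inhibition, read by MTT assay, with a stated time of 24 h, tested at 10 uM; on this read-out higher numbers stand for more inhibition at the one concentration tested (going by the name of the read-out) and lower numbers for less inhibition. Compound 1 `CC(C)=CCOc1cc(=O)n(CCCO)c2c1CC(CC=C(C)C)C(C)(C)C2` gives 7.5%. Compound 2 `CC(C)=CCC1Cc2c(OCCCNS(=O)(=O)c3ccc([N+](=O)[O-])cc3)cc(=O)n(CCCO)c2CC1(C)C` gives 17.3%. Compound 3 `CC(C)=CCC/C(C)=C/CC1Cc2c(OCC=C(C)C)cc(=O)n(CCCO)c2CC1(C)C` gives 15.9%.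

Among these three numbers compound 3 stands second highest. Its nearest neighbour is compound 2, whose number lies within the scatter of compound 3, and its furthest is compound 1, whose number is also within the scatter. Among the compounds with values here, the one step measured so far runs a number 8.4 percentage points higher from compound 1 to compound 3 (within the scatter), and that step adds a group at a different place from the change now considered.

Compound 4 `CC(C)=CCC/C(C)=C/CC1Cc2c(OCCCNC(=O)c3cccs3)cc(=O)n(CCCO)c2CC1(C)C` differs from compound 3 as follows: 2-(((thiophen-2-yl)carbonyl)amino)ethyl in place of 2-methylprop-1-en-1-yl on a saturated chain carbon bound to an oxygen on an aromatic ring. Within the data shown here, no measured step touches this exact place on the core, so the prediction rests on the general picture: every number seen so far sits at a low level, and the one measured step stayed within the scatter. Compound 4 is therefore expected to remain near compound 3, with a change of a number 2.1 percentage points higher from compound 3 to compound 4 (within the scatter) and no movement beyond the scatter. The estimated value for compound 4 in this assay is 18%, within a range from 7% to 32%.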

Compound 4, a percentage reported as inhibition, at one concentration (the size of the read-out at that concentration, not a potency): 11.5%
For compound 4 the middle estimate is 6.5 percentage points above the measured one; the range from low to high includes it.
By their numbers in this assay, from the lowest: compounds 1, 4, 3 and 2 (each within the scatter of the next).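

Within the data shown here, this is the first measured change at the group on a saturated chain carbon bound to an oxygen on an aromatic ring. In this assay, putting 3-(((thiophen-2-yl)carbonyl)amino)propyl in place of 3-methylbut-2-en-1-yl gives a number 4.4 percentage points lower from compound 3 to compound 4 (within the scatter) and so does not carry the number beyond the scatter, even though the entering group is far from a like-for-like swap: it has 10 heavy atoms against 4, a five-membered aromatic ring, 1 hydrogen-bond donor and 2 hydrogen-bond acceptors, where the group leaving has no ring, donor or acceptor. No measurement in hand speaks to why the read-out responds in this way.

The compounds shown leave open whether a simple amine or a carboxylic acid at the end of the propoxy chain, or a longer chain carrying the same (thiophen-2-yl)carbonyl amino group, would move the number beyond the scatter. They also leave open whether this same exchange would read alike on compound 1, which carries the 3-methylbut-2-en-1-yl group in the place where compound 3 has its longer chain.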